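A Second Fluorine on the Amide-Side Ring

A few compounds are considered here, and "the series" means these few. Any claim that something is new, unique, unknown or untested is made for them only; others in the source may bear on it.

Compound 1, `O=C(c1ccc(F)cc1)N1CCc2nc(COc3ccccc3F)oc2C1`, in a functional assay on HEK293 cells for positive allosteric modulation of metabotropic glutamate receptor 5 (Homo sapiens), read by calcium flux; a lower number here means a smaller maximal response, a higher number a larger maximal response: 78%
Compound 2, `O=C(c1ccc(F)cc1)N1CCc2nc(COc3ccc(F)cc3)oc2C1`: 73%
Compound 3, `O=C(c1cccc(F)c1)N1CCc2nc(COc3cccc(F)c3)oc2C1`: 75%

Compound 3 has the middle number of the three, yet compound 2 and compound 1 both sit within the usual scatter of it, so none of the three can be set apart from the others.

Compound 4, `O=C(c1cc(F)cc(F)c1)N1CCc2nc(COc3cccc(F)c3)oc2C1`, differs from compound 3 in one place: fluoro in place of hydrogen on an aromatic carbon. Among the compounds with values here, the only measured step, a number 5 percentage points lower from compound 1 to compound 2 (within the scatter), moves a fluoro group on the other ring, the one on an oxygen on a saturated carbon, and leaves the ring that receives the new fluoro untouched. Within the data shown here, no measured step bears on this change. Without any pointer, no step beyond the scatter is expected, a number 1 percentage points lower from compound 3 to compound 4 (within the scatter). Compound 4 is therefore estimated at 74%, between 58% and 90%.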

Compound 4, largest response reached (reported as percent of maximum), in percent of the reference or control that the assay uses: 42%
Estimate against measurement, compound 4: 32 percentage points above; the whole stated range lies above it.
By their numbers in this assay, from the lowest: compound 4; then compounds 2, 3 and 1 (each within the scatter of the next).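

In this assay, within the data shown here, replacing 3-fluorophenyl with 3,5-difluorophenyl on the amide side gives a number 33 percentage points lower from compound 3 to compound 4 (beyond the scatter), the first step here beyond the scatter. Among these compounds, this position is therefore not indifferent to change: a single added fluoro, just one heavy atom, is enough to lower the maximal response, which the earlier compounds gave no sign of. No supporting measurement bears on why the response falls.

As far as these compounds go, whether a chloro or methoxy group in place of the new fluoro would lower the response too remains open. So does whether the same drop would appear with the fluorine elsewhere on the other ring.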